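This account rests on a few compounds, and the source may have more. Where it says the series, first, only, none or still open, it means among the compounds named here.

Working notes on the series. Going by the values given here, compound 1 `Sc1nnc(-c2ccccc2Cl)o1` gives 680 nM in an assay (Populus sieboldii x Populus grandidentata) for inhibition of Trans-cinnamate 4-monooxygenase (Populus kitakamiensis), with a stated time of 60 min (on this read-out lower numbers stand for stronger inhibition and higher numbers for weaker inhibition), and stands as the lowest of the two numbers so far; compound 2 `Sc1nnc(-c2ccccc2Br)o1` gives 980 nM, and the step of a 1.4-fold higher number from compound 1 to compound 2 (0.16 log units; within the scatter) lies within the scatter. Compound 3 `Sc1nnc(-c2cc(Cl)ccc2Cl)o1` has not yet been measured. Its difference from compound 1 is chloro in place of hydrogen on an aromatic carbon. Among the compounds with values here, no measured step adds a second chloro to the ring; the only measured step, exchanging bromo for chloro at the halogen-bearing carbon, is a 1.4-fold higher number from compound 1 to compound 2 (0.16 log units; within the scatter) and bears on compound 3 only in showing that a change at a halogen on this ring moved the number little. No step beyond the scatter is therefore expected in this assay, in either direction. For compound 3 the expected value is 600 nM, in the range 250 nM to 1600 nM, which means an expected step of a 1.1-fold lower number from compound 1 to compound 3 (0.05 log units; within the scatter).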

Compound 3, half-maximal inhibitory concentration: 2000 nM
Estimate against measurement, compound 3: 3.3-fold (0.52 log units) below; the measured number lies above the stated range.
By their numbers in this assay, from the lowest: compounds 1 and 2 (each within the scatter of the next); then compound 3.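

In this assay, chloro in place of hydrogen on the aromatic carbon para to a chloro group and meta to a group of 6 heavy atoms gives a modest step towards weaker inhibition (a 2.9-fold higher number from compound 1 to compound 3 (0.47 log units; beyond the scatter)), beyond the scatter. This position therefore responds on this read-out, whereas the exchange of bromo for chloro stayed within the scatter (a 1.4-fold higher number from compound 1 to compound 2 (0.16 log units; within the scatter)). No measurement is available that accounts for the step.

Only one group at this carbon is shown, so it remains open whether the step belongs to chloro itself or to any substituent at this place. A methoxy group or an amine at the same carbon, or chloro on another carbon of the ring, would separate these two readings.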